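This account rests on a few compounds, and the source may have more. Where it says the series, first, only, none or still open, it means among the compounds named here.

Measured in a functional assay on HCT-116 cells (Homo sapiens) for inhibition, read by MTT assay, with a stated time of 48 h; a higher number here means a weaker inhibitor, a lower number a stronger inhibitor:
- compound 1 `COc1ccc(N(C)c2nc(C)nc3ccccc23)cc1C(=O)OCC[Se]C#N`: 951 nM
- compound 2 `COc1ccc(N(C)c2nc(C)nc3ccccc23)cc1[Se]C`: 28 nM
- compound 3 `COc1ccc(N(C)c2nc(C)nc3ccccc23)cc1OCCCC[Se]C#N`: 512 nM

Compound 3 has the second highest of these three numbers, but this is no real ranking against compound 1, since the measured step is a 1.9-fold lower number from compound 1 to compound 3 (0.27 log units; within the scatter). Far lower lies compound 2, with the step of an 18-fold higher number from compound 2 to compound 3 (1.26 log units; beyond the scatter).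

Compound 4 `COc1ccc(N(C)c2nc(C)nc3ccccc23)cc1OCCN` is still unmeasured. It differs from compound 3 by one change: one nitrogen atom in place of a group of 5 heavy atoms (3 carbon, 1 nitrogen, 1 selenium; no ring), on a saturated chain carbon, two bonds along the chain from an oxygen on an aromatic ring. Amino enters on a saturated chain carbon, two bonds along the chain from an oxygen on an aromatic ring.

Among the compounds with values here, no measured step makes this exchange, so the evidence is indirect. The steps of a 34-fold lower number from compound 1 to compound 2 (1.53 log units; beyond the scatter) and an 18-fold higher number from compound 2 to compound 3 (1.26 log units; beyond the scatter) show that changes at the aromatic carbon can move the number a long way. Both involve compound 2, however, which has no oxygen on that carbon, whereas compound 3 and compound 4 share one. Within the data shown here, the closest guide is therefore compound 3 at 512 nM, so no step clearly beyond the scatter is expected, with a slight lean towards a lower number. The expected step is a 1.7-fold lower number from compound 3 to compound 4 (0.23 log units; within the scatter). For compound 4 the estimated value is 300 nM, with an expected range of 60 nM to 1500 nM.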

Compound 4, half-maximal inhibitory concentration: 198 nM
The estimate for compound 4 lay 1.5-fold (0.18 log units) above the measured number; measured number inside the range.
By their numbers in this assay, from the lowest: compound 2; then compound 4; then compounds 3 and 1 (each within the scatter of the next).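

Exchanging the selenium-bearing end of the chain for amino gives a real change (a 2.6-fold lower number from compound 3 to compound 4 (0.41 log units; beyond the scatter)), so this end of the chain affects the number, even though the selenium-bearing side chains of compound 1 and compound 3 could not be told apart. Selenium is therefore not needed to reach a number in this range: compound 4 contains none, yet it also stands clear of a second selenium compound (a 4.8-fold lower number from compound 1 to compound 4 (0.68 log units; beyond the scatter)). Removing selenium is still no general route to a lower number, and compound 2 goes against that reading, since its small selenium-bearing group on the aromatic carbon gives a lower number than the amino chain of compound 4 (a 7.1-fold higher number from compound 2 to compound 4 (0.85 log units; beyond the scatter)).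

This single exchange shortens the chain and changes its end together, so the compounds shown cannot separate the effect of chain length from that of amino, which a longer chain ending in amino, or a short chain ending in a dimethylamine or a carboxylic acid, would begin to address. Nothing shown here explains why the amino compound gives the lower number.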